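The source may report more compounds than this note shows. Statements on the series, on what has been measured and on what is new or still open speak of the compounds shown alone.

In a functional assay on HT-29 cells (Homo sapiens) for antiproliferative activity, read by MTT assay, with a stated time of 72 h (a higher number here means a weaker inhibitor, a lower number a stronger inhibitor), compound 1 `CNc1nc(-c2cc(OC)c(OC)c(OC)c2)c(-c2ccc(OC)cc2)s1` gives 6.3 nM. Compound 2 `COc1cc(-c2nc(N(C)C)sc2-c2ccc(C)cc2)cc(OC)c1OC` gives 3920 nM. Compound 3 `COc1cc(-c2nc(N(C)C)sc2-c2ccc(C(F)(F)F)cc2)cc(OC)c1OC` gives > 10000 nM, which is a limit of the assay and not a number.

Compound 4 `COc1ccc(-c2sc(N(C)C)nc2-c2cc(OC)c(OC)c(OC)c2)cc1` has not yet been measured. It differs from compound 3 by methoxy in place of trifluoromethyl on an aromatic carbon, para to a large group.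

For the measured compounds named here, one measured step bears directly on this change: an at least 2.5-fold higher number from compound 2 to compound 3 (0.40 log units; beyond the scatter), seen when trifluoromethyl replaced methyl on an aromatic carbon. Going by these compounds, that step shows that the trifluoromethyl compound gives the higher number, but its full size is unknown. Going by the values given here, no measured step shows what methoxy does in this spot. The 4-methoxyphenyl group does appear in compound 1 at 6.3 nM, which points to a much lower number for compound 4. Compound 2 at 3920 nM argues against expecting a number quite that low.

The expected change is large and downward, towards a stronger inhibitor: an at least 33-fold lower number from compound 3 to compound 4 (1.52 log units; beyond the scatter). For compound 4 the estimated value is 300 nM, with an expected range from 30 nM to 3000 nM.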

Compound 4, half-maximal inhibitory concentration: 497 nM
Compound 4: the middle estimate sits 1.7-fold (0.22 log units) below what was measured; measured number inside the range.
By their numbers in this assay, from the lowest: compound 1; then compound 4; then compound 2. At a limit, above all of these: compound 3.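

In this assay, the identity of the group on this aromatic carbon turns out to matter a great deal, and methoxy gives the lowest number of the three groups seen there: an at least 20-fold lower number from compound 3 to compound 4 (1.30 log units; beyond the scatter) and also a 7.9-fold lower number from compound 2 to compound 4 (0.90 log units; beyond the scatter) when methoxy replaces methyl. With 4-methoxyphenyl held the same, a 79-fold higher number from compound 1 to compound 4 (1.90 log units; beyond the scatter) follows when methyl replaces hydrogen on the nitrogen, so methoxy alone does not bring the low number of compound 1. The first of these steps gives only a minimum size, because compound 3 stands at a limit of the assay and not at a number: the limit of > 10000 nM in this assay, at which 1 of the 4 values shown sits.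

The compounds shown leave open how a hydroxyl, an ethoxy group or a chlorine atom would behave on this aromatic carbon, so the ranking rests on three groups only. It is also open whether methyl or trifluoromethyl would fall in the same order behind methoxy with hydrogen and a single methyl on the nitrogen, since compound 1 is the only compound shown with that arrangement.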